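Changing the end ring of compound 3

The source may report more compounds than this note shows. Statements on the series, on what has been measured and on what is new or still open speak of the compounds shown alone.

Compound 1 `Oc1cccc2[nH]c(-c3ccc(-c4ccc(-c5ccccc5)cc4)cc3)nc12`: 2200 nM
Compound 2 `Oc1ccc(-c2ccc(-c3ccc(-c4nc5c(O)cccc5[nH]4)cc3)cc2)cc1`: 190 nM
Compound 3 `Oc1cccc2[nH]c(-c3ccc(-c4ccc(-c5cccc(Cl)c5)cc4)cc3)nc12`: 3420 nM

All three compounds were tested in a functional assay on MCF7 cells (Homo sapiens) for inhibition, read by sulforhodamine B assay; a higher number here means a weaker inhibitor of growth, a lower number a stronger inhibitor of growth. Here compound 3 gives 3420 nM. That places it close to one neighbour, a 1.6-fold higher number from compound 1 to compound 3 (0.19 log units; within the scatter), and far from the other, an 18-fold higher number from compound 2 to compound 3 (1.26 log units; beyond the scatter).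

Compound 4 `COc1ccc(-c2ccc(-c3ccc(-c4nc5c(O)cccc5[nH]4)cc3)cc2)cc1OC` has not yet been measured. The change is 3,4-dimethoxyphenyl in place of 3-chlorophenyl on an aromatic carbon. In words, this is 3,4-dimethoxyphenyl in place of 3-chlorophenyl on an aromatic carbon, para to a large group.

Two measured steps on the end ring bear on this change. Adding chloro made little difference, a 1.6-fold higher number from compound 1 to compound 3 (0.19 log units; within the scatter). Adding hydroxy made a large one, a 12-fold lower number from compound 1 to compound 2 (1.06 log units; beyond the scatter). So the end ring can matter a great deal, but only compound 2 shows this, and compound 4 carries methoxy groups rather than hydroxy. The large step to compound 2 therefore cannot simply be carried over. Only a modest fall in the number is expected in this assay, one that may not clear the scatter. The estimated step runs a 1.9-fold lower number from compound 3 to compound 4 (0.28 log units; within the scatter). For compound 4 the expected value is 1800 nM, with an estimated range of 500 nM to 5000 nM.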

Compound 4, concentration for 50% growth inhibition: 190 nM
Compound 4: the middle estimate sits 9.5-fold (0.98 log units) above what was measured; measured number below the stated range.
By their numbers in this assay, from the lowest: compounds 2 and 4 (each within the scatter of the next); then compounds 1 and 3 (each within the scatter of the next).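

In this assay, among these compounds, the 3,4-dimethoxyphenyl end ring brings a large step, an 18-fold lower number from compound 3 to compound 4 (1.26 log units; beyond the scatter), and a large step against the plain phenyl ring as well, a 12-fold lower number from compound 1 to compound 4 (1.06 log units; beyond the scatter), so compound 2 is no longer the only compound showing that this position can strongly change the number. It also stands level with the 4-hydroxyphenyl end ring, no change at the digits printed from compound 2 to compound 4 (within the scatter), which shows that a hydroxy group on the end ring is not required for a low number here: the 3,4-dimethoxyphenyl group counts 0 hydrogen-bond donors and 2 hydrogen-bond acceptors, and among these four compounds, the two with oxygen on the end ring sit low, while the unsubstituted and chloro end rings sit high, with no compound going against this. Nothing available explains why these end rings give such different numbers.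

The compounds shown leave open whether a single methoxy group would be enough or whether both are needed. On these data alone, how an end ring carrying an amine or a carboxylic acid would behave at this position also remains open.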